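The source may hold more compounds than are shown below. What is called first, only, known or untested is meant among the compounds shown, and "the series" means these compounds.

Measured so far in a functional assay on HCT-116 cells (Homo sapiens) for antiproliferative activity, read by MTT assay; on this read-out higher numbers stand for weaker inhibition and lower numbers for stronger inhibition:

compound 1 `Cn1c(=O)c(=O)n(C2CCCC2)c2nc(N/N=C/c3ccccc3)ncc21` — > 100000 nM (a limit of the assay, not a number)
compound 2 `Cc1cc(C)c(/C=N/Nc2ncc3c(n2)n(C2CCCC2)c(=O)c(=O)n3C)c(C)c1` — 7920 nM
compound 3 `Cn1c(=O)c(=O)n(C2CCCC2)c2nc(N/N=C/c3ccc(F)cc3Cl)ncc21` — 13800 nM

Compound 3 gives the highest of the two numbers in this assay; its nearest neighbour is compound 2, and the gap a 1.7-fold higher number from compound 2 to compound 3 (0.24 log units; within the scatter) lies within the scatter. Compound 1 sits at the limit (the limit of > 100000 nM in this assay, at which 1 of the 3 values shown sits).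

Compound 4 `Cn1c(=O)c(=O)n(C2CCCC2)c2nc(N/N=C/c3ccccc3Cl)ncc21` differs from compound 3 only in hydrogen in place of fluoro on an aromatic carbon. For the measured compounds named here, no measured step removes a single fluoro from this ring. The steps that touch the same ring are an at least 12-fold lower number from compound 1 to compound 2 (1.10 log units; beyond the scatter) and an at least 7.2-fold lower number from compound 1 to compound 3 (0.86 log units; beyond the scatter), both from the unsubstituted phenyl to a substituted one and both beyond the scatter, while a 1.7-fold higher number from compound 2 to compound 3 (0.24 log units; within the scatter) shows that the two substituted rings sit within the scatter of each other. Compound 4 keeps the chloro group and loses only the fluoro, so the expected step of a 1.2-fold higher number from compound 3 to compound 4 (0.06 log units; within the scatter) is small, within the scatter, with no clear direction. Compound 4 is estimated at 16000 nM, expected between 6000 nM and 45000 nM.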

Compound 4, half-maximal inhibitory concentration: 14000 nM
Estimate against measurement, compound 4: 1.1-fold (0.06 log units) above; low and high end bracket the measured number.
By their numbers in this assay, from the lowest: compounds 2, 3 and 4 (each within the scatter of the next). At a limit, above all of these: compound 1.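

Hydrogen and fluoro at this place, meta to a chloro group and para to a large group, cannot be told apart in this assay (a 1.0-fold higher number from compound 3 to compound 4 (0.01 log units; within the scatter)). With the chloro group as the only substituent, the ring already gives a step beyond the scatter from the unsubstituted phenyl (an at least 7.1-fold lower number from compound 1 to compound 4 (0.85 log units; beyond the scatter)), and 2-chlorophenyl cannot be told apart from 2,4,6-trimethylphenyl (a 1.8-fold higher number from compound 2 to compound 4 (0.25 log units; within the scatter)). That step from the unsubstituted phenyl has a bound on one side only, because compound 1 stands at a limit and not at a number: (the limit of > 100000 nM in this assay, at which 1 of the 4 values shown sits).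

Open, going by these compounds, is whether this place also accepts a methoxy group, an amine or a carboxylic acid without a step beyond the scatter. Also open, on these data alone, is whether a ring carrying only a fluoro group, with no chloro group, gives a number or stays at a limit as compound 1 does.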